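From Dichlorophenyl Urea to Trifluoromethylphenyl Urea

The source may hold more compounds than are shown below. What is called first, only, known or untested is meant among the compounds shown, and "the series" means these compounds.

Compound 1 `COc1cc(Cl)cc(-c2nn(-c3cccc(NC(=O)c4ccc(Cl)c(Cl)c4)c3)cc2-c2ccncc2)c1` — 61.4%
Compound 2 `COc1cc(Cl)cc(-c2nn(-c3cccc(NC(=O)Nc4ccc(Cl)c(Cl)c4)c3)cc2-c2ccncc2)c1` — 8.59%

In a functional assay on NCI/ADR-RES cells (Homo sapiens) for inhibition, read by sulforhodamine B assay, with a stated time of 48 h, tested at 10 uM (on this read-out higher numbers stand for a weaker effect at the one concentration tested and lower numbers for a stronger effect), compound 1 gives 61.4% and compound 2 gives 8.59%. For the measured compounds named here, compound 2 stands lowest of the two numbers, and the only measured step, a number 52.8 percentage points lower from compound 1 to compound 2 (beyond the scatter), separates it from compound 1. Compound 3 `COc1cc(Cl)cc(-c2nn(-c3cccc(NC(=O)Nc4cccc(C(F)(F)F)c4)c3)cc2-c2ccncc2)c1` carries 3-(trifluoromethyl)phenyl in place of 3,4-dichlorophenyl on an amide-type nitrogen. Going by the values given here, this keeps the urea of compound 2 and alters only the aryl on an amide-type nitrogen, a change no measured step covers, so the expected step of a number 9.4 percentage points higher from compound 2 to compound 3 (within the scatter) is small, within the scatter or a modest rise. Compound 3 is estimated at 18% in this assay, between 5% and 45%.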

Compound 3, a percentage reported as activity, at one concentration (the size of the read-out at that concentration, not a potency): 3.58%
Beside the measured number, compound 3's estimate is 14.4 percentage points above it, outside the stated range (below it).
By their numbers in this assay, from the lowest: compounds 3 and 2 (each within the scatter of the next); then compound 1.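

In this assay, the step at the aryl on an amide-type nitrogen reads a number 5 percentage points lower from compound 2 to compound 3 (within the scatter), so 3-(trifluoromethyl)phenyl and 3,4-dichlorophenyl cannot be told apart here. The urea's advantage is therefore not confined to 3,4-dichlorophenyl, as the second aryl also shows a large step, a number 57.8 percentage points lower from compound 1 to compound 3 (beyond the scatter). No available evidence accounts for either step. On these data alone, it remains open whether an unsubstituted phenyl, a 4-(trifluoromethyl)phenyl or a nitrile-bearing phenyl would read the same, and whether a saturated cyclohexyl could replace the aryl on the urea.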